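The compounds below may be only part of what the source reports. "The series", "measured", "known", "first", "only" and "open" are said of these compounds alone.

Of the compounds shown here, two sharing one core have so far been tested in an assay on isolated protein for inhibition of Rho-associated protein kinase 2 (Homo sapiens), read by scintillation counting, radiometric assay and 33P incorporation, with a stated time of 40 min, in the presence of a further agent that is not named here; on this read-out lower numbers stand for stronger inhibition and higher numbers for weaker inhibition. Compound 1 `CN(C)c1ccc(C(=O)Nc2cccc(NC(=O)COc3ccc4occc(=O)c4c3)c2)cc1` gives only a limit of this assay, > 10000 nM, rather than a number; that is the entry described as the limit of > 10000 nM in this assay, at which 1 of the 2 values shown sits. Among the measured compounds shown here, compound 2 `CCCc1ccc(C(=O)Nc2cccc(NC(=O)COc3ccc4c(=O)ccoc4c3)c2)cc1` gives 14 nM in this assay, the only true number among the values shown. Compound 3 `Cc1cc(C(=O)Nc2cccc(NC(=O)COc3ccc4c(=O)ccoc4c3)c2)ccc1C(F)(F)F` has not yet been measured. It differs from compound 2 in a single place: a group of 11 heavy atoms (8 carbon, 3 fluorine; one six-membered aromatic ring of carbon only) in place of a group of 9 heavy atoms (9 carbon; one six-membered aromatic ring of carbon only), on a carbonyl carbon. For the measured compounds named here, no measured pair of compounds shows a change of just this kind, so no size of step can be read off from the numbers at hand. The change is expected to leave the read-out of this assay close to that of compound 2, within or only slightly beyond the usual scatter, which is what the expected step of a 2.1-fold higher number from compound 2 to compound 3 (0.33 log units; beyond the scatter) means. For compound 3 the estimate is 30 nM, with a range from 8 nM to 150 nM.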

Compound 3, half-maximal inhibitory concentration: 43 nM
Estimate against measurement, compound 3: 1.4-fold (0.16 log units) below; the range from low to high includes it.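

Among the compounds shown here, the first step that can be read at this place, on a carbonyl carbon whose other neighbour is an amide-type nitrogen, is a 3.1-fold higher number from compound 2 to compound 3 (0.49 log units; beyond the scatter) in this assay. The step is modest, so swapping 4-propylphenyl for an aromatic ring carrying methyl and trifluoromethyl groups weakens inhibition only somewhat, and compound 3 still gives a true number, 43 nM, rather than a limit. Nothing measured here explains why the number rises.

A single step cannot separate the effect of losing the propyl chain from the effect of adding the methyl or the trifluoromethyl group. On these data alone, it also remains open how this assay would read with an amine, a carboxylic acid or a longer chain on the aromatic ring at this place.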